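Chloro in place of hydrogen across two related cores

The compounds below may be only part of what the source reports. "The series", "measured", "known", "first", "only" and "open" are said of these compounds alone.

Compound 1 `COc1cccc(S(=O)(=O)/C=C/c2ccccn2)c1` gives 2170 nM in an assay on U2OS cells for activation of nuclear factor erythroid 2-related factor 2 (Homo sapiens), read by chemiluminescence, with a stated time of 6 h; on this read-out higher numbers stand for an effect only at larger amounts of compound and lower numbers for an effect already at smaller amounts. Compound 2 `COc1cccc(S(=O)(=O)/C=C/c2ncccc2Cl)c1` carries the change chloro in place of hydrogen on an aromatic carbon and gives 98 nM in this assay, a step of a 22-fold lower number from compound 1 to compound 2 (1.35 log units; beyond the scatter). Compound 3 `COc1ccc(S(=O)(=O)/C=C/c2ccccn2)cc1` has the same atoms as compound 1 joined differently; the difference between the two cores is not broken down here. In this assay compound 3 gives only a limit, > 10000 nM, at the limit of > 10000 nM in this assay, at which 1 of the 3 values shown sits. Compound 4 `COc1ccc(S(=O)(=O)/C=C/c2ccc(Cl)cn2)cc1` differs from compound 3 by chloro in place of hydrogen on an aromatic carbon; the chloro here sits para to a large group rather than ortho to it, so this is the same kind of change, not the same one. For compound 4 a step of an at least 3.3-fold lower number from compound 3 to compound 4 (0.52 log units; beyond the scatter) is expected, resting on a 22-fold lower number from compound 1 to compound 2 (1.35 log units; beyond the scatter) but starting from a limit. Compound 4 is therefore estimated at 3000 nM, between 500 nM and 15000 nM.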

Compound 4, half-maximal effective concentration: 9360 nM
Compound 4: middle estimate off by 3.1-fold (0.49 log units), on the low side, and the stated range covers the measured number.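

On the core of compound 3, the change reads in this assay only as an at least 1.0-fold lower number from compound 3 to compound 4 (0.02 log units; that floor lies within the scatter). Compound 3 stands at a limit, > 10000 nM, and not at a number. The change therefore cannot be said to carry over from one core to the other with or without its size, and the chloro also occupies a different place in compound 4 than in compound 2: the same change on two cores in this assay, a 22-fold lower number (1.35 log units; beyond the scatter) from compound 1 to compound 2 and an at least 1.0-fold lower number (0.02 log units; that floor lies within the scatter) from compound 3 to compound 4; the limit leaves it open whether they differ

Open, as far as these compounds go, is how chloro would act on the core of compound 3 in the place it holds in compound 2. Also open, from the compounds shown here alone, is whether a group other than chloro on the pyridine-type ring, such as fluoro, methyl or an amine, would give a similar step on either core.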